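Allyl ether variant of the chroman thiazolidinedione series

The compounds below may be only part of what the source reports. "The series", "measured", "known", "first", "only" and "open" are said of these compounds alone.

Compound 1 `C=CCOc1c(C)c(C)c2c(c1C)CCC(C)(COc1ccc(/C=C3\SC(=O)NC3=O)cc1)O2`: 45%
Compound 2 `C=CCOc1c(C)c(C)c2c(c1C)CCC(C)(COc1ccc(/C=C3\SC(=O)NC3=O)cc1OC)O2`: 34%
Compound 3 `CC(C)=CCOc1c(C)c(C)c2c(c1C)CCC(C)(COc1ccc(/C=C3\SC(=O)NC3=O)cc1C)O2`: 89%

In a functional assay on MCF7 cells (Homo sapiens), tested at 2.5 uM (on this read-out higher numbers stand for a weaker effect at the one concentration tested and lower numbers for a stronger effect), compound 3 stands highest of the three, beyond the scatter from both compound 1 and compound 2. Compound 4 `C=CCOc1c(C)c(C)c2c(c1C)CCC(C)(COc1ccc(/C=C3\SC(=O)NC3=O)cc1C)O2` is not yet measured; it differs from compound 3 by vinyl in place of 2-methylprop-1-en-1-yl on a saturated chain carbon bound to an oxygen on an aromatic ring. For the measured compounds named here, the only measured step, a number 11 percentage points lower from compound 1 to compound 2 (beyond the scatter), concerns a different change and does not bear on this one. Still, both compounds that carry the same allyloxy group as compound 4 give far lower numbers than compound 3: compound 1 gives 45% and compound 2 gives 34%. Compound 4 is therefore expected to show a step of a number 39 percentage points lower from compound 3 to compound 4 (beyond the scatter), a lower number, and an estimated value of 50%, within 30% to 80%.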

Compound 4, a percentage reported as activity, at one concentration (the size of the read-out at that concentration, not a potency): 84%
For compound 4 the middle estimate is 34 percentage points below the measured one; measured number outside the range, above it.
By their numbers in this assay, from the lowest: compound 2; then compound 1; then compounds 4 and 3 (each within the scatter of the next).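

In this assay the exchange of (3-methylbut-2-en-1-yl)oxy for allyloxy gives a number 5 percentage points lower from compound 3 to compound 4 (within the scatter) and so, with methyl on the aromatic carbon, does not separate the two compounds. Among the allyloxy compounds the aromatic carbon carries the large steps: methyl in place of hydrogen gives a number 39 percentage points higher from compound 1 to compound 4 (beyond the scatter) and methyl in place of methoxy gives a number 50 percentage points higher from compound 2 to compound 4 (beyond the scatter) as the second large step. Nothing measured here gives a reason for these steps.

Going by these compounds, it remains open whether the exchange of 3-methylbut-2-en-1-yl for allyl stays within the scatter with hydrogen or methoxy on that aromatic carbon, and how an amine or a fluorine there would compare.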